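The compounds below may be only part of what the source reports. "The series", "measured", "known", "first", "only" and "open" are said of these compounds alone.

Three compounds share one core, and each has been tested in an ADME assay on HEL cells (Homo sapiens) for cytotoxicity, read by microscopy; on this read-out lower numbers stand for higher toxicity in this test and higher numbers for lower toxicity in this test. Compound 1, `O=C(N/N=C/c1cccc(Cl)c1)c1cccnc1`, gives 53 ug/mL in this assay. Compound 3, `O=C(N/N=C/c1cccc(Br)c1)c1cccnc1`, gives 55 ug/mL. The two are tied by one structural change, (bromo in place of chloro on an aromatic carbon), and the step it made is a 1.0-fold higher number from compound 1 to compound 3 (0.02 log units; within the scatter). Compound 2, `O=C(N/N=C/c1ccc(Cl)cc1)c1cccnc1`, gives 29 ug/mL in this assay; how its core differs from the core of compound 1 is not broken down here.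

Compound 4, `O=C(N/N=C/c1ccc(Br)cc1)c1cccnc1`, has not yet been measured in this assay. It differs from compound 2 by bromo in place of chloro on an aromatic carbon. Going by the values given here, this is the same kind of change as the one from compound 1 to compound 3, though the place is not the same, the earlier one sitting meta to a large group and this one para to a large group. Because the earlier step was a 1.0-fold higher number from compound 1 to compound 3 (0.02 log units; within the scatter), a similarly small step is expected here as well, and the estimate for compound 4 rests on compound 2 giving 29 ug/mL. The expected step is a 1.1-fold higher number from compound 2 to compound 4 (0.03 log units; within the scatter), so compound 4 is estimated at 31 ug/mL, with a plausible range from 18 ug/mL to 55 ug/mL.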

Compound 4, half-maximal cytotoxic concentration: 48 ug/mL
For compound 4 the middle estimate is 1.5-fold (0.19 log units) below the measured one; low and high end bracket the measured number.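

In this assay, putting bromo in place of chloro on an aromatic carbon para to a large group gives a 1.7-fold higher number from compound 2 to compound 4 (0.22 log units; within the scatter). Set beside the same swap on the other core, this step does not differ from the earlier one by more than repeated measurements would: the same change on two cores in this assay, a 1.0-fold higher number (0.02 log units; within the scatter) from compound 1 to compound 3 and a 1.7-fold higher number (0.22 log units; within the scatter) from compound 2 to compound 4, 1.6-fold (0.20 log units) apart, within the scatter of two such steps. In both pairs, then, the swap carries over with a step no larger than the scatter, but two pairs in one assay show no more than that: they cannot separate a small real difference between the two places from ordinary scatter, and they do not show that the swap would behave this way on other cores.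

The compounds shown carry only chloro or bromo on this ring, which leaves open how the read-out would respond to a fluoro group, a methoxy group or an amine in these places. Also open, from the compounds shown here alone, is whether the swap would still give so small a step on a ring that carries a second group, such as a carboxylic acid.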